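The compounds below may be only part of what the source reports. "The series", "measured", "known", "first", "only" and "open" are said of these compounds alone.

Two compounds share one core and differ only in the group on an amide-type nitrogen. Compound 1 `CCc1ccc(NC(=O)c2csc(Cc3c(Cl)cccc3Cl)n2)cc1` carries 4-ethylphenyl there, and in an assay on CHO cells, read by calcium flux (a lower number here means a stronger inhibitor, a higher number a weaker inhibitor), compound 1 gives 1450 nM. Compound 2 `O=C(Nc1ccc(Br)cn1)c1csc(Cc2c(Cl)cccc2Cl)n1` carries 5-bromopyridin-2-yl instead. In this assay compound 2 reaches only the limit of the assay, > 4000 nM, so no number is known for it. The change between them reads an at least 2.7-fold higher number from compound 1 to compound 2 (0.44 log units; beyond the scatter), and compound 2 stands at the limit of > 4000 nM in this assay, at which 1 of the 2 values shown sits, the weaker end of what has been seen.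

Compound 3 `O=C(Nc1cccc(Br)c1)c1csc(Cc2c(Cl)cccc2Cl)n1` has not yet been measured. It differs from compound 2 by 3-bromophenyl in place of 5-bromopyridin-2-yl on an amide-type nitrogen. A ring of carbon only thus comes back onto the amide-type nitrogen, though 3-bromophenyl is not the 4-ethylphenyl of compound 1. Within the data shown here, the only measured step that bears on this, an at least 2.7-fold higher number from compound 1 to compound 2 (0.44 log units; beyond the scatter), went the other way and was at least modest, so reversing part of it points toward a lower number, with the bromine position as the unknown. The expected step is an at least 1.6-fold lower number from compound 2 to compound 3 (0.20 log units; that floor lies within the scatter). Compound 3 is therefore estimated at 2500 nM, between 800 nM and 8000 nM.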

Compound 3, half-maximal inhibitory concentration: > 4000 nM
Compound 3: no number, only a limit; the forecaster's own chance of this, stated with the estimate: 35%; middle value at least 1.6-fold (0.20 log units) away from the limit.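

Replacing 4-ethylphenyl with 3-bromophenyl on the amide-type nitrogen gives, in this assay, an at least 2.7-fold higher number from compound 1 to compound 3 (0.44 log units; beyond the scatter), so this second change also moves the number up by at least a modest amount. Putting a ring of carbon only back at this position therefore does not by itself restore a measurable number, and the ring nitrogen of 5-bromopyridin-2-yl cannot be the whole story behind the weak result for compound 2. The step between compound 2 and compound 3 cannot be read, and no order can be given for them, because both stand at the same limit of the assay: the limit of > 4000 nM in this assay, at which 2 of the 3 values shown sit.

The compounds shown leave open whether the higher number from compound 1 follows from the arrival of bromine, from the loss of the ethyl group, or from where the substituent sits on the ring. Plain phenyl, 4-bromophenyl and 3-ethylphenyl on the same amide-type nitrogen would pull these apart, and a 4-propylphenyl would show whether a longer chain can go further than the 4-ethylphenyl of compound 1.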